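Swapping methyl for chloro on an inactive thiophene amine

A few compounds are considered here, and "the series" means these few. Any claim that something is new, unique, unknown or untested is made for them only; others in the source may bear on it.

Compound 1 `COC(=O)c1c(Nc2ccc(Cl)cc2)sc(C(=O)c2ccc(C)cc2)c1C` – "not active" (no number reported)
Compound 2 `Cc1ccc(C(=O)c2sc(Nc3ccccc3)c(C(=O)O)c2C)cc1` – 1.25%
Compound 3 `Cc1ccc(Nc2sc(C(=O)c3ccc(C)cc3)c(C)c2C(=O)O)cc1` – "not active" (no number reported)

Three close relatives share one core and were tested in a functional assay, with a stated time of 150 min, tested at 15 ug/mL; a higher number here means a stronger effect of the compound at the concentration tested, a lower number a weaker effect. Compound 2 gives 1.25% in this assay, a read-out so small that it sits within the ordinary scatter of the method. Compound 1 is reported in this assay as "not active" (no number reported), without a number. Compound 3 stands in the same place: in this assay compound 3 is reported as "not active" (no number reported), again with no number attached. So none of the three shows an effect worth separating from noise, and compound 3 in particular has no figure of its own to build on.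

Compound 4 `Cc1ccc(C(=O)c2sc(Nc3ccc(Cl)cc3)c(C(=O)O)c2C)cc1` has not yet been measured. It differs from compound 3 in one spot: chloro in place of methyl on an aromatic carbon. Within the data shown here, no pair of measured compounds shows this exact swap, so there is nothing to lean on beyond the flat picture above. The expectation is therefore no step beyond the scatter in this assay, in either direction. Compound 4 is estimated to give 1% in this assay, with a likely range from 0% to 8%, and a real chance that only "not active" is reported.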

Compound 4, a percentage reported as activity, at one concentration (the size of the read-out at that concentration, not a potency): "not active" (no number reported)
Compound 4: no number reported; the estimate stays without a comparison.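

Compound 4 is reported as "not active" (no number reported) in this assay and compound 3 likewise has no number, so no step can be read for the change from 4-methylphenyl to 4-chlorophenyl. No supporting data bear on this result. Among these compounds, whether this swap alters the effect at all remains open, with no figure for either compound.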